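A few compounds are considered here, and "the series" means these few. Any claim that something is new, unique, unknown or untested is made for them only; others in the source may bear on it.

Measured compounds in the series:

Compound 1, `CC(C)(C)c1ccc(NC(=O)Nc2cccc(CNc3ncnc4ccccc34)c2)cc1`: 17900 nM
Compound 2, `O=C(Nc1cccc(CNc2ncnc3ccccc23)c1)Nc1ccccc1F`: 26100 nM
Compound 3, `O=C(Nc1ccc(F)cc1)Nc1cccc(CNc2ncnc3ccccc23)c1`: 21000 nM

All three share the same core and differ only in the aryl group on the urea nitrogen. In a functional assay on A549 cells (Homo sapiens) for antiproliferative activity, read by MTT assay (a lower number here means a stronger inhibitor, a higher number a weaker inhibitor), compound 3 gives 21000 nM, which places it second highest of the three numbers; its nearest neighbour is compound 1 and its furthest is compound 2, and both gaps lie within the scatter. The steps measured so far are a 1.2-fold higher number from compound 1 to compound 3 (0.07 log units; within the scatter), a 1.5-fold higher number from compound 1 to compound 2 (0.16 log units; within the scatter) and a 1.2-fold lower number from compound 2 to compound 3 (0.09 log units; within the scatter); none of them reaches beyond the scatter, so the three aryl groups seen here are not separated by this assay.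

Compound 4, `O=C(Nc1cccc(CNc2ncnc3ccccc23)c1)Nc1ccccc1Cl`, is not yet measured. It differs from compound 3 by 2-chlorophenyl in place of 4-fluorophenyl on an amide-type nitrogen. The step most closely related is a 1.2-fold lower number from compound 2 to compound 3 (0.09 log units; within the scatter), where the halogen also moved from one position on the phenyl to another without a change beyond the scatter. For the measured compounds named here, exchanging fluorine for chlorine has no measured precedent in this set. On that basis no step beyond the scatter is expected, and compound 4 is estimated at 24000 nM, with a range from 10000 nM to 55000 nM, meaning an expected step of a 1.1-fold higher number from compound 3 to compound 4 (0.06 log units; within the scatter).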

Compound 4, half-maximal inhibitory concentration: 18000 nM
For compound 4 the middle estimate is 1.3-fold (0.12 log units) above the measured one; the range from low to high includes it.
By their numbers in this assay, from the lowest: compounds 1, 4, 3 and 2 (each within the scatter of the next).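

In this assay, for the compounds shown here, the exchange of fluoro for chloro on an aromatic carbon, which had no precedent among the earlier steps, reads a 1.5-fold lower number from compound 2 to compound 4 (0.16 log units; within the scatter) and so does not separate these two halogens at this position. The replacement of 4-fluorophenyl by 2-chlorophenyl on the amide-type nitrogen, which changes both the halogen and its place on the ring, reads a 1.2-fold lower number from compound 3 to compound 4 (0.07 log units; within the scatter) and the replacement of 4-(tert-butyl)phenyl by 2-chlorophenyl reads a 1.0-fold higher number from compound 1 to compound 4 (0.00 log units; within the scatter) so all four aryl groups among compound 1, compound 2, compound 3 and compound 4 now lie within the scatter of one another, with none going against this flat picture. No measured evidence is available to explain why these groups are not separated.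

Open, from the compounds shown here alone, is whether any group on this nitrogen moves the number beyond the scatter, for instance a phenyl carrying an amine, a carboxylic acid, a methoxy group or a nitrile, or a pyridine ring in place of the phenyl. Also open, going by these compounds, is how a longer chain between the urea nitrogen and the aryl ring would read, and whether a change in the shared core would matter more than any of these aryl exchanges.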